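This account rests on a few compounds, and the source may have more. Where it says the series, first, only, none or still open, it means among the compounds named here.

The measured compounds:

Compound 1, `CCC(C)C(=O)Nc1c(C(O)(C(F)(F)F)C(F)(F)F)ccc2ccccc12` — 177000 nM
Compound 2, `CC(C)=CC(=O)Nc1c(C(O)(C(F)(F)F)C(F)(F)F)ccc2ccccc12` — 46 nM
Compound 3, `COCC(=O)Nc1c(C(O)(C(F)(F)F)C(F)(F)F)ccc2ccccc12` — 213 nM

In an assay on LtK cells with ATP-sensitive inward rectifier potassium channel 11 (Homo sapiens) as the target (on this read-out lower numbers stand for an effect already at smaller amounts and higher numbers for an effect only at larger amounts of compound), compound 1 stands highest of the three numbers; its nearest neighbour is compound 3 and its furthest is compound 2, and both steps away from it are large: a 3800-fold lower number from compound 1 to compound 2 (3.59 log units; beyond the scatter) and an 830-fold lower number from compound 1 to compound 3 (2.92 log units; beyond the scatter). Compound 2 and compound 3 lie apart from one another by a smaller margin, a 4.6-fold higher number from compound 2 to compound 3 (0.67 log units; beyond the scatter).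

Compound 4, `O=C(NCCCCCCCl)Nc1c(C(O)(C(F)(F)F)C(F)(F)F)ccc2ccccc12`, has not yet been measured. It differs from compound 1 in one place: (6-chlorohexyl)amino in place of sec-butyl on a carbonyl carbon. Both measured steps from compound 1 bear on this change, since each replaces sec-butyl on the carbonyl carbon and each lowers the number by a large margin. The group entering here is not one already tested, so the size of the effect is uncertain, but the direction is expected to follow those two steps. Compound 4 is therefore expected to give 1000 nM, with a range from 50 nM to 20000 nM, a step estimated as a 180-fold lower number from compound 1 to compound 4 (2.25 log units; beyond the scatter).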

Compound 4, half-maximal effective concentration: 4840 nM
Compound 4: the middle estimate sits 4.8-fold (0.68 log units) below what was measured; measured number inside the range.
By their numbers in this assay, from the lowest: compound 2; then compound 3; then compound 4; then compound 1.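

In this assay, a change that puts a nitrogen on the carbonyl carbon and brings in a chlorine-ended chain, (sec-butyl)carbonyl to (6-chlorohexyl)carbamoyl, still gives a 37-fold lower number from compound 1 to compound 4 (1.56 log units; beyond the scatter), so the fall on leaving sec-butyl is not confined to the two smaller carbon-linked groups. The new group nevertheless stays well short of both earlier replacements, with a 23-fold higher number from compound 3 to compound 4 (1.36 log units; beyond the scatter) and a 110-fold higher number from compound 2 to compound 4 (2.02 log units; beyond the scatter), so what enters at this carbonyl carbon sets how far the number falls, not merely the loss of sec-butyl. Nothing available here accounts for these differences.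

The compounds shown leave open how much of this rests on the amino nitrogen, the chlorine or the chain length. A plain hexylamino group, a shorter butylamino chain or a 6-chlorohexyl chain bound through carbon alone would separate these parts.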